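This account rests on a few compounds, and the source may have more. Where it says the series, first, only, none or still open, it means among the compounds named here.

Compound 1 `COc1ccc(C2N=C(SCc3ccc(Cl)cc3)NC(C)=C2C(=O)Nc2ccc(F)cc2)cc1OC` and compound 2 `COc1ccc(C2N=C(SCc3ccc(F)cc3)NC(C)=C2C(=O)Nc2ccc(F)cc2)cc1OC` are built on one shared core and differ only in fluoro in place of chloro on an aromatic carbon. In a functional assay on the whole organism (artery, strain albino) with Rattus norvegicus as the target, with a stated time of 60 min, at a dose of 10 mg/kg by the oral route (a lower number here means less inhibition, a higher number more inhibition at the dose given (going by the name of the read-out)), compound 1 gives 10.3%, and compound 2 gives 11.8%, a step of a number 1.5 percentage points higher from compound 1 to compound 2 (within the scatter). Compound 3 `CC1=C(C(=O)Nc2ccc(Br)cc2)C(c2ccc(Cl)cc2Cl)N=C(SCc2ccc(Cl)cc2)N1` rests on a different core; how that core differs from the core of compound 1 is not broken down here. In this assay compound 3 gives 11.8%, level with compound 2 at the digits shown and within the scatter of compound 1. Compound 4 `CC1=C(C(=O)Nc2ccc(Br)cc2)C(c2ccc(Cl)cc2Cl)N=C(SCc2ccc(F)cc2)N1` is made from compound 3 by the same change, (fluoro in place of chloro on an aromatic carbon), at a place described in the same words. Because the measured pair showed only a number 1.5 percentage points higher from compound 1 to compound 2 (within the scatter) for this change, a similarly small step is expected here: a number 0.7 percentage points higher from compound 3 to compound 4 (within the scatter). Compound 4 is therefore estimated at 12.5%, with a likely range from 3% to 23%.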

Compound 4, a percentage reported as inhibition, in the whole organism at one dose (the size of the read-out at that dose, not a potency): 16.9%
The estimate for compound 4 lay 4.4 percentage points below the measured number; the measured number falls inside the stated range.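

In this assay, fluoro in place of chloro gives a number 5.1 percentage points higher from compound 3 to compound 4 (within the scatter). Set beside the earlier step, the change carries over from one core to the other with no difference that can be told apart: the same change on two cores in this assay, a number 1.5 percentage points higher (within the scatter) from compound 1 to compound 2 and a number 5.1 percentage points higher (within the scatter) from compound 3 to compound 4, 3.6 percentage points apart, within the scatter of two such steps. Within the data shown here, this shows only that the step stays small on both cores at this one dose; with just two pairs, each within the scatter, it does not show that fluoro and chloro truly differ on either core, or that a further core would behave the same way.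

The compounds shown leave open what an amine or a carboxylic acid would do in place of the halogen on this ring. They also leave open whether a longer chain in place of the benzyl would change the picture.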